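Moving a chloro group on the triazole aryl of a terpenoid ester

A few compounds are considered here, and "the series" means these few. Any claim that something is new, unique, unknown or untested is made for them only; others in the source may bear on it.

Measured so far:
Compound 1 `C/C(=C\CC/C(C)=C/CC[C@@H]1[C@@]2(C)CCC(=O)C(C)(C)[C@H]2CC[C@@]1(C)O)CC/C=C(\C)C(=O)OCc1cn(-c2cccc(O)c2)nn1` gives 28400 nM
Compound 2 `C/C(=C\CC/C(C)=C/CC[C@@H]1[C@@]2(C)CCC(=O)C(C)(C)[C@H]2CC[C@@]1(C)O)CC/C=C(\C)C(=O)OCc1cn(-c2ccccc2C)nn1` gives > 150000 nM
Compound 3 `C/C(=C\CC/C(C)=C/CC[C@@H]1[C@@]2(C)CCC(=O)C(C)(C)[C@H]2CC[C@@]1(C)O)CC/C=C(\C)C(=O)OCc1cn(-c2cccc(Cl)c2)nn1` gives 103000 nM

All three share one core and differ only in the aryl group on the triazole nitrogen, tested in a functional assay on DU-145 cells (Homo sapiens) for antiproliferative activity, read by MTT assay, with a stated time of 48 h; on this read-out higher numbers stand for weaker inhibition and lower numbers for stronger inhibition. For compound 2 the number is only a limit of this assay (the limit of > 150000 nM in this assay, at which 1 of the 3 values shown sits), not a measured value. From compound 1 the step to compound 3 was a 3.6-fold higher number from compound 1 to compound 3 (0.56 log units; beyond the scatter), and the step of an at least 1.4-fold lower number from compound 2 to compound 3 (0.16 log units; that floor lies within the scatter) ran from a limit.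

Compound 4 `C/C(=C\CC/C(C)=C/CC[C@@H]1[C@@]2(C)CCC(=O)C(C)(C)[C@H]2CC[C@@]1(C)O)CC/C=C(\C)C(=O)OCc1cn(-c2ccc(Cl)cc2)nn1` carries the change (4-chlorophenyl in place of 2-methylphenyl on an aromatic nitrogen). Since the step to compound 3 moved a chloro group onto the same position type without a value beyond the scatter, a comparable outcome is expected, so the step of an at least 1.5-fold lower number from compound 2 to compound 4 (0.17 log units; that floor lies within the scatter) is estimated. Compound 4 is expected to give 100000 nM, within 35000 nM to 160000 nM.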

Compound 4, half-maximal inhibitory concentration: > 150000 nM
Compound 4: a limit, no number (the forecaster's own chance of this, stated with the estimate: 35%); middle value at least 1.5-fold (0.17 log units) from the limit.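

In this assay compound 4 gives > 150000 nM, which is a limit and not a number, and compound 2 stands at that same limit: the limit of > 150000 nM in this assay, at which 2 of the 4 values shown sit.

The change from 3-chlorophenyl to 4-chlorophenyl gives an at least 1.4-fold higher number from compound 3 to compound 4 (0.16 log units; that floor lies within the scatter), so the two chloro placements are not separated beyond the scatter, whereas the change from 3-hydroxyphenyl gives an at least 5.2-fold higher number from compound 1 to compound 4 (0.72 log units; beyond the scatter). The step between the two compounds at the limit cannot be read.

As far as these compounds go, the true value of compound 4 stays open. So does whether an amine or a carboxylic acid in place of the hydroxy group of compound 1 would match its number.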